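Swapping Bromo for Fluoro on a Sulfonamide Pair

The source may report more compounds than this note shows. Statements on the series, on what has been measured and on what is new or still open speak of the compounds shown alone.

Of the compounds shown here, three sharing one core have been measured in an ADME assay on MT4 cells (Homo sapiens) for cytotoxicity, read by MTT assay, with a stated time of 5 days; a lower number here means that less compound is tolerated, a higher number that more compound is tolerated. Compound 1 `Cc1cc(C#N)cc(C)c1Oc1nc(NC2CCC(NC(=O)c3ccc(F)cc3)CC2)nc2ccsc12` gives 3180 nM in this assay. Compound 2 `Cc1cc(C#N)cc(C)c1Oc1nc(NC2CCC(NC(=O)c3ccc(Br)cc3)CC2)nc2ccsc12` gives 2850 nM in this assay, and compound 3 `Cc1cc(C#N)cc(C)c1Oc1nc(NC2CCC(NS(=O)(=O)c3ccc(Br)cc3)CC2)nc2ccsc12` gives 5860 nM in this assay.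

Compound 1 differs from compound 2 by fluoro in place of bromo on an aromatic carbon, and this change made a 1.1-fold higher number from compound 2 to compound 1 (0.05 log units; within the scatter). Compound 3 differs from compound 2 by (4-bromophenyl)sulfonyl in place of (4-bromophenyl)carbonyl on an amine nitrogen, which made a 2.1-fold higher number from compound 2 to compound 3 (0.31 log units; beyond the scatter). Between compound 1 and compound 3 the step was a 1.8-fold higher number from compound 1 to compound 3 (0.27 log units; within the scatter). Compound 3 thus stands with the highest number of the three, though only its gap to compound 2 is beyond the scatter.

Compound 4 `Cc1cc(C#N)cc(C)c1Oc1nc(NC2CCC(NS(=O)(=O)c3ccc(F)cc3)CC2)nc2ccsc12` has not yet been measured in this assay. It differs from compound 3 by fluoro in place of bromo on an aromatic carbon. The place of this change is described in the same words as for the change from compound 2 to compound 1, so it is the same change, now made on the core of compound 3 rather than that of compound 2.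

Compound 4 is expected to show a 1.0-fold higher number from compound 3 to compound 4 (0.01 log units; within the scatter) in this assay, a step of about the same size as the earlier one, because a 1.1-fold higher number from compound 2 to compound 1 (0.05 log units; within the scatter) was within the scatter. On that basis compound 4 is estimated to give 6000 nM in this assay, with an expected range from 3000 nM to 12000 nM.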

Compound 4, half-maximal cytotoxic concentration: 3530 nM
Compound 4: middle estimate off by 1.7-fold (0.23 log units), on the high side; measured number inside the range.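

Fluoro in place of bromo on the core of compound 3 gave a 1.7-fold lower number from compound 3 to compound 4 (0.22 log units; within the scatter), and in this assay this step cannot be told apart from the earlier one: the same change on two cores in this assay, a 1.1-fold higher number (0.05 log units; within the scatter) from compound 2 to compound 1 and a 1.7-fold lower number (0.22 log units; within the scatter) from compound 3 to compound 4, 1.9-fold (0.27 log units) apart, within the scatter of two such steps. Among the compounds shown here, compound 4 also lies within the scatter of both carbonyl compounds, with a 1.2-fold higher number from compound 2 to compound 4 (0.09 log units; within the scatter) and a 1.1-fold higher number from compound 1 to compound 4 (0.05 log units; within the scatter), so the gap beyond the scatter seen between the bromo pair has no counterpart in either step to compound 4. The two cores therefore give no sign that the change behaves differently from one to the other, but they do not prove that it behaves the same or that it has any effect at all, as both steps lie within the scatter and two cores are too few to make a rule for the series.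

The compounds shown leave open whether a chloro, methyl or methoxy group at the same place on the aromatic ring would give a step beyond the scatter on either core. They also leave open how a plain methylene link or a urea in place of the carbonyl or sulfonyl group would read in this assay.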